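Removing the tert-butoxycarbonyl group from compound 3

The compounds below may be only part of what the source reports. "The series", "measured", "known", "first", "only" and "open" are said of these compounds alone.

Measured compounds:
Compound 2 `CC(C)(C)OC(=O)NCCCNC(=O)CN1CN(c2ccccc2)C2(CCN(C(=O)c3ccc(C4CCCCC4)cc3)CC2)C1=O`: 6000 nM
Compound 3 `CC(C)(C)OC(=O)NCCCNC(=O)CN1CN(c2ccccc2)C2(CCN(C(=O)c3ccc(C(C)(C)C)cc3)CC2)C1=O`: 4500 nM
Compound 1 `CCc1nn(CC)c(C2CCN(C(=O)CN3CN(c4ccccc4)C4(CCN(C(=O)c5ccc(C6CCCCC6)cc5)CC4)C3=O)CC2)c1C`: "not determined" (no result reported)

All numbers come from an assay on HEK293 cells for displacement of a labelled ligand from NPC1-like intracellular cholesterol transporter 1 (Homo sapiens); on this read-out higher numbers stand for weaker inhibition and lower numbers for stronger inhibition. Going by the values given here, only one pair of measured compounds differs in a single place: a 1.3-fold lower number from compound 2 to compound 3 (0.12 log units; within the scatter), a change of tert-butyl in place of cyclohexyl on an aromatic carbon. Since that step lies within the scatter, compound 3 and compound 2 cannot be ranked against each other on this assay; compound 3 simply sits beside compound 2, and compound 1 adds no number.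

Compound 4 `CC(C)(C)c1ccc(C(=O)N2CCC3(CC2)C(=O)N(CC(=O)NCCCN)CN3c2ccccc2)cc1` is made from compound 3 by a change at a different part of the molecule: hydrogen in place of tert-butoxycarbonyl on an amine nitrogen. Among the compounds with values here, none of the measured steps touches this amine nitrogen; the single measured step concerns a group on the aromatic ring and therefore says nothing about what happens when the tert-butoxycarbonyl group is taken away. Within the data shown here, with no step to lean on, the expected change from compound 3 to compound 4 is no change at the digits printed from compound 3 to compound 4 (within the scatter), a number near that of compound 3 but with a wide band of uncertainty in either direction. Compound 4 is therefore estimated at 4500 nM, expected to fall between 1200 nM and 17000 nM.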

Compound 4, half-maximal inhibitory concentration: 4200 nM
Estimate against measurement, compound 4: 1.1-fold (0.03 log units) above; the range from low to high includes it.
By their numbers in this assay, from the lowest: compounds 4, 3 and 2 (each within the scatter of the next).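

In this assay, taking the tert-butoxycarbonyl group off the amine nitrogen gives a 1.1-fold lower number from compound 3 to compound 4 (0.03 log units; within the scatter). Both earlier compounds with a number carried this group, so they could not show whether it counts for anything; here 7 heavy atoms, including 2 hydrogen-bond acceptors, leave that nitrogen, and the two compounds still cannot be told apart on this read-out, so in this pair the tert-butoxycarbonyl group can go without a change that rises above the usual scatter. No measurement is at hand that explains this result.

The compounds shown leave open whether other groups on this amine nitrogen, such as an acetyl or a methyl group, would also stay within the scatter, and whether a longer chain carrying the amine would read the same. They also leave open whether the same removal would read alike in compound 2, where cyclohexyl takes the place of tert-butyl on the aromatic ring.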